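The source may report more compounds than this note shows. Statements on the series, on what has been measured and on what is new or still open speak of the compounds shown alone.

Measured so far: compound 1 `O=C(Nc1cccc(-n2cc(-c3ccncc3)c(-c3ccc(Cl)c(O)c3)n2)c1)Nc1cccc(C(F)(F)F)c1` with 1820 nM; compound 2 `COc1cc(-c2nn(-c3cccc(NC(=O)c4cccc(C(F)(F)F)c4)c3)cc2-c2ccncc2)ccc1Cl` with 838 nM; compound 3 `COc1cc(-c2nn(-c3cccc(NC(=O)Nc4ccc(Cl)c(Cl)c4)c3)cc2-c2ccncc2)ccc1Cl` with 932 nM.

In a functional assay on SR cells (Homo sapiens) for inhibition, read by sulforhodamine B assay, with a stated time of 48 h (on this read-out higher numbers stand for weaker inhibition of growth and lower numbers for stronger inhibition of growth), compound 3 stands second highest of the three numbers; compound 2 lies nearest and within the scatter, and compound 1, the furthest, is also within the scatter. Compound 4 `COc1cc(-c2nn(-c3cccc(NC(=O)Nc4cccc(C(F)(F)F)c4)c3)cc2-c2ccncc2)ccc1Cl` has not been measured. It differs from compound 3 in one place: 3-(trifluoromethyl)phenyl in place of 3,4-dichlorophenyl on an amide-type nitrogen. For the measured compounds named here, one measured step bears on this: a 1.1-fold higher number from compound 2 to compound 3 (0.05 log units; within the scatter), which ran the same aryl exchange in the reverse direction together with a change on the carbonyl carbon. Compound 1 and compound 2 both carry the entering group and sit within the scatter of compound 3. No step beyond the scatter is therefore expected in this assay. The expected step is a 1.1-fold higher number from compound 3 to compound 4 (0.03 log units; within the scatter). Compound 4 is estimated at 1000 nM, within 450 nM to 2200 nM.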

Compound 4, concentration for 50% growth inhibition: 886 nM
The estimate for compound 4 lay 1.1-fold (0.05 log units) above the measured number; low and high end bracket the measured number.
By their numbers in this assay, from the lowest: compounds 2, 4, 3 and 1 (each within the scatter of the next, the first and the last beyond it).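

In this assay, for the compounds shown here, the exchange on the amide-type nitrogen, seen alone for the first time, stays small (a 1.1-fold lower number from compound 3 to compound 4 (0.02 log units; within the scatter)), and the (3-(trifluoromethyl)phenyl)amino group on the carbonyl carbon does not separate its pair either (a 1.1-fold higher number from compound 2 to compound 4 (0.02 log units; within the scatter)). Going by these compounds alone, the only step beyond the scatter lies elsewhere, with methyl in place of hydrogen on the oxygen, and it is modest (a 2.1-fold lower number from compound 1 to compound 4 (0.31 log units; beyond the scatter)). No measurement shown gives a reason for any of these steps. From the compounds shown here alone, whether an amine or a carboxylic acid on that aryl ring would move the number stays open.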